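Lengthening an Already Long Chain on a Weak Inhibitor

The compounds below may be only part of what the source reports. "The series", "measured", "known", "first", "only" and "open" are said of these compounds alone.

In a functional assay, with stated times of 30 s and 6 min, in the presence of a further agent that is not named here (a lower number here means a stronger inhibitor, a higher number a weaker inhibitor), compound 1 (`COc1cc(O)c(C(C)=O)cc1Br`) reads 15600000 nM and compound 2 (`CCOc1cc(OC)c(Br)cc1C(C)=O`) reads 37900000 nM while compound 3 (`CCCCCCCCOc1cc(OC)c(Br)cc1C(C)=O`) reads 30900000 nM (within the scatter of both others). Compound 4 (`CCCCCCCCCCCCCCCCOc1cc(OC)c(Br)cc1C(C)=O`) extends the chain of compound 3 further, and the change is octyl in place of hydrogen on a saturated chain carbon, eight bonds along the chain from an oxygen on an aromatic ring (the octyl sits at the chain's far end). The closest guide is the hexyl step (a 1.2-fold lower number from compound 2 to compound 3 (0.09 log units; within the scatter)) which stayed within the scatter. The ethyl step (a 2.4-fold higher number from compound 1 to compound 2 (0.39 log units; beyond the scatter)) was modest and replaced a hydrogen on an oxygen, so it is a weaker guide. In this assay the estimated step (a 1.0-fold lower number from compound 3 to compound 4 (0.01 log units; within the scatter)) is therefore expected to stay within the scatter. Compound 4 is estimated at 30000000 nM with an expected range from 12000000 nM to 70000000 nM on repeated measurement.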

Compound 4, half-maximal inhibitory concentration: 1800000 nM
Compound 4: middle estimate off by 17-fold (1.22 log units), on the high side; measured number below the stated range.
By their numbers in this assay, from the lowest: compound 4; then compounds 1, 3 and 2 (each within the scatter of the next, the first and the last beyond it).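

Adding octyl at this position, eight bonds along the chain from an oxygen on an aromatic ring, gives the first large change tied to chain length in this assay (a 17-fold lower number from compound 3 to compound 4 (1.23 log units; beyond the scatter)). The earlier hexyl addition stayed within the scatter, so lengthening the chain does not change the number evenly across compound 2, compound 3 and compound 4. Nothing available here explains this drop. Going by these compounds, whether a longer chain would lower the number further remains open. So does whether an amine or a carboxylic acid at the chain's far end would keep the lower number.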